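The source may hold more compounds than are shown below. What is called first, only, known or untested is meant among the compounds shown, and "the series" means these compounds.

Working notes on the series. Among the measured compounds shown here, compound 2, `O=C(CCl)N(/N=N/c1ccc([N+](=O)[O-])cc1C(F)(F)F)c1ccc([N+](=O)[O-])cc1C(F)(F)F`, gives 800 nM in a functional assay on HeLa cells (Homo sapiens) for cytotoxicity, read by MTT assay, with a stated time of 72 h (a higher number here means a weaker inhibitor, a lower number a stronger inhibitor), the lower of the two numbers measured so far; compound 1, `O=C(c1ccccc1C(F)(F)F)N(/N=N/c1ccc([N+](=O)[O-])cc1C(F)(F)F)c1ccc([N+](=O)[O-])cc1C(F)(F)F`, gives 5350 nM in this assay. For the measured compounds named here, the one step measured, a 6.7-fold lower number from compound 1 to compound 2 (0.83 log units; beyond the scatter), replaces the whole group on the carbonyl carbon, and the shared core with its two nitro-bearing rings is kept throughout.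

Compound 3, `CCOC(=O)CC(=O)N(/N=N/c1ccc([N+](=O)[O-])cc1C(F)(F)F)c1ccc([N+](=O)[O-])cc1C(F)(F)F`, is compound 2 with ethoxycarbonyl in place of chloro on a saturated chain carbon bound to a carbonyl carbon. Going by the values given here, no measured pair carries this exchange; the only step to hand, a 6.7-fold lower number from compound 1 to compound 2 (0.83 log units; beyond the scatter), is at the same carbonyl but swaps a different group, so it is a loose guide at best. It shows that the acyl group can move this assay by a modest amount. For compound 3 the number is expected to sit above that of compound 2, with a step of about a 3.1-fold higher number from compound 2 to compound 3 (0.49 log units; beyond the scatter) in this assay, though a value within the scatter would not surprise. Estimated value for compound 3 in this assay: 2500 nM, range 700 nM to 9000 nM.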

Compound 3, half-maximal inhibitory concentration: 300 nM
For compound 3 the middle estimate is 8.3-fold (0.92 log units) above the measured one, and the stated range ends above it.
By their numbers in this assay, from the lowest: compound 3; then compound 2; then compound 1.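

In this assay the chloro group on the saturated chain carbon bound to a carbonyl carbon is not required for the lower number: ethoxycarbonyl in its place gives a 2.7-fold lower number from compound 2 to compound 3 (0.43 log units; beyond the scatter) and makes compound 3 the lowest of the three. Over the whole acyl exchange the series shows an 18-fold lower number from compound 1 to compound 3 (1.25 log units; beyond the scatter) and this large step, unlike the earlier modest one, shows that a chain without chlorine can also stand at this carbonyl. No measurement at hand accounts for either step.

As far as these compounds go, whether the gain needs the ethoxycarbonyl group itself remains open, and a carboxylic acid, an amide or a plain longer alkyl chain on the same carbon would test this. Also open, from the compounds shown here alone, is whether a simple methyl on the carbonyl carbon would give a similar number.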